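The source may hold more compounds than are shown below. What is called first, only, known or untested is meant among the compounds shown, and "the series" means these compounds.

Three compounds share one core and differ only in the group bound to its aromatic nitrogen. In a functional assay on cells (Platelet, Homo sapiens) for inhibition (on this read-out lower numbers stand for stronger inhibition and higher numbers for weaker inhibition), compound 2 `CCOC(=O)c1ccc(-c2nn(Cc3ccccc3F)c3ccccc23)cc1` gives 110 nM, the lowest number of the three. Compound 1 `CCOC(=O)c1ccc(-c2nn(Cc3ccccc3Cl)c3ccccc23)cc1` gives 230 nM in this assay, and compound 3 `CCOC(=O)c1ccc(-c2nn(-c3ccoc3)c3ccccc23)cc1` gives 580 nM. The step of a 2.1-fold lower number from compound 1 to compound 2 (0.32 log units; beyond the scatter) is the smaller move; the step of a 5.3-fold higher number from compound 2 to compound 3 (0.72 log units; beyond the scatter) is the larger one, and a 2.5-fold higher number from compound 1 to compound 3 (0.40 log units; beyond the scatter) lies between them. Compound 4 `CCOC(=O)c1ccc(-c2nn(CC)c3ccccc23)cc1` has not yet been measured. It differs from compound 2 in one place: methyl in place of 2-fluorophenyl on a saturated chain carbon bound to an aromatic nitrogen. Going by the values given here, no measured step removes an aromatic ring from this position entirely; the nearest guide is the step from compound 2 to compound 3, where putting furan-3-yl in place of 2-fluorobenzyl already gave a weaker number. Taking the ring away altogether is therefore expected to give a step in this assay toward a higher number, and a 14-fold higher number from compound 2 to compound 4 (1.13 log units; beyond the scatter) is the expected size of that step. Compound 4 is estimated at 1500 nM, with a range from 400 nM to 6000 nM.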

Compound 4, half-maximal inhibitory concentration: 360 nM
Estimate against measurement, compound 4: 4.2-fold (0.62 log units) above; measured number below the stated range.
By their numbers in this assay, from the lowest: compound 2; then compounds 1, 4 and 3 (each within the scatter of the next, the first and the last beyond it).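

The change from 2-fluorobenzyl to ethyl gives a 3.3-fold higher number from compound 2 to compound 4 (0.51 log units; beyond the scatter) in this assay, so inhibition at this position does not depend on keeping an aromatic ring on the chain. Only the 2-fluorobenzyl group stands clear of ethyl, however: a 1.6-fold higher number from compound 1 to compound 4 (0.19 log units; within the scatter) lies within the scatter, so 2-chlorobenzyl cannot be told apart from ethyl. The same holds for furan-3-yl, with a 1.6-fold lower number from compound 3 to compound 4 (0.21 log units; within the scatter) also within the scatter, which means that compound 1, compound 3 and compound 4 read alike in pairs with compound 4, and only the 2-fluorobenzyl group of compound 2 gives a clear advantage over ethyl.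

Still open, as far as these compounds go, is how an unsubstituted benzyl, a longer chain such as butyl, or a chain ending in an amine would read on this aromatic nitrogen. Nothing measured here explains why the 2-fluorobenzyl group outperforms ethyl while the 2-chlorobenzyl group does not.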